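The source may report more compounds than this note shows. Statements on the series, on what has been measured and on what is new or still open speak of the compounds shown alone.

Compound 1: `CCn1c(C(=O)NCCN)ccc1C(CC)(CC)c1ccc(OCCC(O)(CC)CC)c(C)c1` — 156 nM
Compound 2: `CCn1c(C(=O)Nc2ccc(OC(F)(F)F)cc2)ccc1C(CC)(CC)c1ccc(OCCC(O)(CC)CC)c(C)c1` — > 10000 nM

In an assay on cells for agonist activity at vitamin D3 receptor (Homo sapiens), with a stated time of 96 h (on this read-out higher numbers stand for an effect only at larger amounts of compound and lower numbers for an effect already at smaller amounts), compound 1 gives 156 nM. For compound 2 the same assay reports only a limit, > 10000 nM, so its true number is not known. Going by the values given here, the single measured step, an at least 64-fold higher number from compound 1 to compound 2 (1.80 log units; beyond the scatter), owes its stated size to the limit of > 10000 nM in this assay, at which 1 of the 2 values shown sits. Compound 3 is `CCn1c(C(=O)NC(C)C(=O)O)ccc1C(CC)(CC)c1ccc(OCCC(O)(CC)CC)c(C)c1`; it differs from compound 2 by 1-carboxyethyl in place of 4-(trifluoromethoxy)phenyl on an amide-type nitrogen. This change moves back from the ring of compound 2 to a short chain, as in compound 1, so the step is expected to run downward, an at least 40-fold lower number from compound 2 to compound 3 (1.60 log units; beyond the scatter). Compound 3 is estimated at 250 nM, between 50 nM and 3000 nM.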

Compound 3, half-maximal effective concentration: 66 nM
Compound 3: middle estimate off by 3.8-fold (0.58 log units), on the high side; low and high end bracket the measured number.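

With 1-carboxyethyl on the amide-type nitrogen, a second short chain now gives a measured number, so the effect at smaller amounts seen with compound 1 does not depend on 2-aminoethyl alone. The change from 2-aminoethyl to 1-carboxyethyl gives a 2.4-fold lower number from compound 1 to compound 3 (0.37 log units; beyond the scatter). The change from the ring-bearing group gives an at least 150-fold lower number from compound 2 to compound 3 (2.18 log units; beyond the scatter), but compound 2 has only a limit, which sets the stated size of this step: the limit of > 10000 nM in this assay, at which 1 of the 3 values shown sits.

The compounds shown leave open whether a plain phenyl ring would behave like 4-(trifluoromethoxy)phenyl. They also leave open whether a longer chain ending in a carboxylic acid or an amine would keep an effect at such small amounts.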